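The source may report more compounds than this note shows. Statements on the series, on what has been measured and on what is new or still open speak of the compounds shown alone.

Working notes on the series.

Compound 1 `CC(C(=O)NCc1ccc(C(F)(F)F)cc1N1CCC(C)(C)CC1)c1ccc(NS(C)(=O)=O)c(F)c1` and compound 2 `C[C@H](C(=O)NCc1ccc(C(F)(F)F)cc1SC1CCCCC1)c1ccc(NS(C)(=O)=O)c(F)c1` share the same core and have both been measured in an assay on CHO cells for antagonist activity at transient receptor potential cation channel subfamily V member 1 (Homo sapiens), read by FLIPR; on this read-out lower numbers stand for stronger inhibition and higher numbers for weaker inhibition. Compound 1 gives 1.3 nM and compound 2 gives 0.3 nM; compound 1 thus stands with the higher of the two numbers, and the gap to compound 2 lies beyond the scatter of repeat measurements.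

Compound 3 `COc1ccc(CSc2cc(C(F)(F)F)ccc2CNC(=O)C(C)c2ccc(NS(C)(=O)=O)c(F)c2)cc1` has not yet been measured. It differs from compound 1 in one place: (4-methoxybenzyl)sulfanyl in place of 4,4-dimethylpiperidin-1-yl on an aromatic carbon. Among the compounds with values here, no measured pair of this series shows this particular change, so the size of the step can only be expected, not read off. Compound 2, which also carries a sulfanyl-linked substituent on its core, gives 0.3 nM in this assay, and that is the nearest guide available. On this basis compound 3 is expected to show a small downward step from compound 1, a 1.6-fold lower number from compound 1 to compound 3 (0.21 log units; within the scatter), which should remain within or close to the usual scatter. The estimate for compound 3 in this assay is 0.8 nM, with a range from 0.25 nM to 3 nM.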

Compound 3, inhibition constant: 2.3 nM
Beside the measured number, compound 3's estimate is 2.9-fold (0.46 log units) below it; measured number inside the range.
By their numbers in this assay, from the lowest: compound 2; then compounds 1 and 3 (each within the scatter of the next).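

In this assay, within the data shown here, the exchange of 4,4-dimethylpiperidin-1-yl for (4-methoxybenzyl)sulfanyl gives a 1.8-fold higher number from compound 1 to compound 3 (0.25 log units; within the scatter), the first one-place step that can be read at this position, on an aromatic carbon ortho to a large group and meta to a trifluoromethyl group. The position therefore takes a carbon-only aromatic ring on a sulfanyl link in place of a six-membered non-aromatic ring with a hetero atom, with 10 heavy atoms entering for 8 leaving, and the two compounds remain within the scatter of each other. No measured information is available to account for this result.

The compounds shown leave open what the methoxy group and the sulfur link each contribute, which a plain benzylsulfanyl group or a benzyloxy group at the same place would help to separate. Also open, on these data alone, is how far this tolerance extends to groups of a different kind on this aromatic carbon, such as a carboxylic acid or a primary amine.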